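Changing the group on the carbonyl of compound 2

This account rests on a few compounds, and the source may have more. Where it says the series, first, only, none or still open, it means among the compounds named here.

Measured in a functional assay on MDA-MB-231 cells (Homo sapiens) for cytotoxicity, read by MTT assay, with a stated time of 48 h; a lower number here means a stronger inhibitor, a higher number a weaker inhibitor:
- Compound 1 `C=C1CC[C@@H]2[C@](C)(COC(=O)CC)[C@H](OC(=O)CC)CC[C@@]2(C)[C@@H]1CCc1ccoc1`: 40400 nM
- Compound 2 `C=C1CC[C@@H]2[C@](C)(COC(=O)COc3ccccc3)[C@H](O)CC[C@@]2(C)[C@@H]1CCc1ccoc1`: 35000 nM

Compound 2 at 35000 nM lies within the usual scatter of compound 1 at 40400 nM, so the two cannot be ranked. Compound 3 `C=C1CC[C@@H]2[C@](C)(COC(=O)c3ccc(OC)cc3)[C@H](O)CC[C@@]2(C)[C@@H]1CCc1ccoc1` has 4-methoxyphenyl in place of phenoxymethyl on a carbonyl carbon. For the measured compounds named here, no pair of measured compounds differs in one place only, so the data show no direct precedent for this change. In this assay, no shift beyond the scatter is expected, and the estimated step is a 1.1-fold lower number from compound 2 to compound 3 (0.04 log units; within the scatter). For compound 3 the expected value is 32000 nM, with an estimated range of 14000 nM to 75000 nM.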

Compound 3, half-maximal inhibitory concentration: 28600 nM
Beside the measured number, compound 3's estimate is 1.1-fold (0.05 log units) above it, within the range that was stated.
By their numbers in this assay, from the lowest: compounds 3, 2 and 1 (each within the scatter of the next).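

In this assay the first one-place comparison appears: 4-methoxyphenyl in place of phenoxymethyl on a carbonyl carbon gives a step within the scatter (a 1.2-fold lower number from compound 2 to compound 3 (0.09 log units; within the scatter)). The two groups count the same atoms, and joining them differently produces no readable shift at this position. No measured evidence explains this result.

Still open, as far as these compounds go, is whether a group without an aromatic ring on this carbonyl, such as a longer alkyl chain or an amine, would move the number beyond the scatter. Whether a carboxylic acid would do so is equally unknown.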